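Stereochemistry and Plasma Protein Binding in a Matched Pair

A few compounds are considered here, and "the series" means these few. Any claim that something is new, unique, unknown or untested is made for them only; others in the source may bear on it.

Measured so far:
compound 1, `CN(C)S(=O)(=O)N(C)[C@@H]1CCCn2c1nc(C(=O)NCc1ccc(F)cc1)c(O)c2=O`: 81%
compound 2, `CN(C)C(=O)C(=O)N(C)[C@H]1CCCCn2c1nc(C(=O)NCc1ccc(F)cc1)c(O)c2=O`: 81%

Two compounds have been characterised in an ADME assay on a cell-free system (plasma, Homo sapiens) for protein binding, with Plasma (Rattus norvegicus) as the target. In this assay compound 1 gives 81%, and compound 2 gives 81%. The two values sit level at the digits shown, so compound 1 stands within the scatter of compound 2, and no step between them can be read.

The next compound is compound 3, `CN(C)S(=O)(=O)N(C)[C@H]1CCCn2c1nc(C(=O)NCc1ccc(F)cc1)c(O)c2=O`, which has not yet been measured in this assay. It is related to compound 1 as follows: the two compounds have the same atoms and bonds and differ only in configuration as drawn: 1 of 1 stereo elements differ; a stereocentre at a saturated ring carbon is drawn R in compound 1 and S in compound 3. Going by the values given here, no comparable step between measured compounds is available, so the expectation for compound 3 rests on the level result of compound 1 and compound 2 alone. The step of no change at the digits printed from compound 1 to compound 3 (within the scatter) is expected to show no change beyond the scatter. Compound 3 is thus estimated to give 81%, with a range from 70% to 89%.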

Compound 3, plasma protein binding: 87%
Compound 3: middle estimate off by 1.5-fold (0.16 log units) (unbound fraction), on the high side; the measured number falls inside the stated range.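

In this assay, going by these compounds alone, compounds 1 and 3 give the first reading of a change at this saturated ring carbon, where the stereocentre is drawn R in compound 1 and S in compound 3, and the step is a 1.5-fold lower unbound fraction from compound 1 to compound 3 (0.16 log units; within the scatter). Inverting this stereocentre therefore leaves the read-out within the usual scatter, so these data separate no effect of the drawn configuration at this position. The comparison is confined to one place: the fact that compounds 1 and 3 differ only in the configuration as drawn.

On these data alone, whether the configuration at this carbon would count for as little in compound 2 remains open. So does whether the same would hold with a carboxylic acid or an amine on the side chain in place of the sulfonamide.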